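Amide replacement in an alkyne-bearing series

The source may hold more compounds than are shown below. What is called first, only, known or untested is meant among the compounds shown, and "the series" means these compounds.

Measured so far:
Compound 1 `O=C(C1CCC1)N1CCc2nc(C#Cc3ccccc3)sc2C1` — 370 nM
Compound 2 `O=C(CC1CCOCC1)N1CCc2nc(C#Cc3ccccc3)sc2C1` — > 10000 nM

In an assay on HEK293 cells for negative allosteric modulation of metabotropic glutamate receptor 5 (Homo sapiens), read by FLIPR, with a stated time of 1 h (on this read-out lower numbers stand for stronger inhibition and higher numbers for weaker inhibition), compound 1 gives 370 nM. For compound 2 the read-out is a limit, > 10000 nM, and not a number; this sits at the limit of > 10000 nM in this assay, at which 1 of the 2 values shown sits. Within the data shown here, the one measured step, an at least 27-fold higher number from compound 1 to compound 2 (1.43 log units; beyond the scatter), is therefore known only as a lower bound and stands at the weak end of the numbers seen.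

Compound 3 `O=C(c1cccc(Cl)c1)N1CCc2nc(C#Cc3ccccc3)sc2C1` differs from compound 2 by 3-chlorophenyl in place of (oxan-4-yl)methyl on a carbonyl carbon. Among the measured compounds shown here, no measured step covers this exact exchange; the only step that bears on it is the large loss from compound 1 to compound 2, which was driven by a change at the same carbonyl carbon. With the (oxan-4-yl)methyl group leaving again, the expectation is a step in the opposite direction, back toward the region of compound 1: for compound 3 the estimated step is an at least 33-fold lower number from compound 2 to compound 3 (1.52 log units; beyond the scatter), and the expected value in this assay is 300 nM, with a range from 50 nM to 3000 nM.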

Compound 3, half-maximal inhibitory concentration: > 10000 nM
Compound 3: no number, only a limit; the forecaster's own chance of this, stated with the estimate: 15%; middle value at least 33-fold (1.52 log units) away from the limit.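

In this assay compound 3 also reads as a limit, > 10000 nM, and not a number. The loss at this carbonyl carbon is therefore not tied to (oxan-4-yl)methyl: it also appears with 3-chlorophenyl, which carries no hydrogen-bond acceptor and has a ring of carbon only, with an at least 27-fold higher number from compound 1 to compound 3 (1.43 log units; beyond the scatter). The exchange from compound 2 to compound 3 cannot be read, as both ends are limits, and cyclobutyl in compound 1 remains the only group shown here that gives a number, with the rest of the series at the assay's limit: the limit of > 10000 nM in this assay, at which 2 of the 3 values shown sit.

Still open, from the compounds shown here alone, is how far the group on the carbonyl carbon can grow from cyclobutyl before the number is lost. Cyclopentyl, or a phenyl ring without the chlorine, would help to locate that point.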